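The source may hold more compounds than are shown below. What is called first, only, known or untested is meant among the compounds shown, and "the series" means these compounds.

Compound 1 `Cn1c(-c2ccccc2F)nnc1[S+](C)[O-]` and compound 2 `Cn1c(-c2ccccc2F)nnc1S(C)(=O)=O` share one core, while compound 3 `Cn1nc([S+](C)[O-])nc1-c1ccccc1` and compound 4 `Cn1nc(S(C)(=O)=O)nc1-c1ccccc1` share another; the difference between the two cores is not broken down here. In a functional assay on the whole organism for antagonist activity, with Mus musculus as the target (a lower number here means that less compound is needed, a higher number that more compound is needed for the effect), compound 1 reaches only a limit of > 200 mg/kg. In this assay compound 2 likewise reaches only a limit of > 100 mg/kg. The change from compound 1 to compound 2 is a group of 4 heavy atoms (1 carbon, 2 oxygen, 1 sulfur; no ring) in place of a group of 3 heavy atoms (1 carbon, 1 oxygen, 1 sulfur; no ring), on an aromatic carbon, and the step that the two limits leave unreadable from compound 1 to compound 2 cannot be read. In this assay compound 3 also reaches only a limit of > 200 mg/kg. The change from compound 3 to compound 4 is a group of 4 heavy atoms (1 carbon, 2 oxygen, 1 sulfur; no ring) in place of a group of 3 heavy atoms (1 carbon, 1 oxygen, 1 sulfur; no ring), on an aromatic carbon, the same kind of change: here the place is two ring bonds from the ring atom that bears a methyl group, whereas in compound 1 it is next to the ring atom that bears a methyl group. Of the three values, one sits at the limit of > 100 mg/kg in this assay, at which 1 of the 3 values shown sits, and two sit at the limit of > 200 mg/kg in this assay, at which 2 of the 3 values shown sit. Compound 4 is expected to show a step that the limit leaves unreadable from compound 3 to compound 4, resting on the unreadable step that the two limits leave unreadable from compound 1 to compound 2. Compound 4 is estimated in this assay at 300 mg/kg, between 100 mg/kg and 1000 mg/kg, most likely again only a limit.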

Compound 4, dose for half-maximal effect: > 200 mg/kg
Compound 4 ended at the assay's limit; the forecaster's own chance of this, stated with the estimate: 85%; the middle value lies beyond the limit too.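

In this assay compound 4 gives > 200 mg/kg, which is a limit of the assay and not a number. With compound 3 also at a limit, no step can be read between compound 3 and compound 4. The compounds shown leave open what dose, if any, methylsulfonyl in place of the smaller group would require on either core.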